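This account rests on a few compounds, and the source may have more. Where it says the series, first, only, none or still open, it means among the compounds named here.

Measured compounds:
Compound 1, `OC(c1ccccc1)(c1ccccc1)c1ccccc1Cl`: 2100 nM
Compound 2, `Oc1ccccc1C(O)(c1ccccc1)c1ccccc1`: 800 nM; 3300 nM (2 entries)
Compound 3, `Oc1ccccc1C(O)(c1ccccc1)c1ccccc1Cl`: 1000 nM

All three were tested in a functional assay on NIH3T3 cells (Mus musculus) for antiproliferative activity; a higher number here means a weaker inhibitor, a lower number a stronger inhibitor. Among the two compounds with a single number, compound 1 stands highest; its nearest neighbour is compound 3, and the step of a 2.1-fold lower number from compound 1 to compound 3 (0.32 log units; beyond the scatter) counts as modest. Compound 2 has been tested more than once, and the several entries of compound 2 in this assay, 800 nM; 3300 nM (2 entries) shows how far repeat measurements of one compound can sit apart in this kind of test.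

The next compound, compound 4, `O=[N+]([O-])c1ccc(C(O)(c2ccccc2)c2ccccc2)c(Cl)c1`, is compound 1 with a single change: nitro in place of hydrogen on an aromatic carbon. Within the data shown here, no measured step here involves a nitro group. Among the measured compounds shown here, the one measured step, hydroxy in place of hydrogen on an aromatic carbon, a 2.1-fold lower number from compound 1 to compound 3 (0.32 log units; beyond the scatter), is the only guide to how much one added substituent on this core shifts the number, and it was modest. The expectation for compound 4 in this assay is therefore a step of a 1.1-fold lower number from compound 1 to compound 4 (0.02 log units; within the scatter) that stays within the usual scatter, with no clear direction. Compound 4 is estimated at 2000 nM, with a likely range from 600 nM to 7000 nM.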

Compound 4, half-maximal inhibitory concentration: 300 nM
Compound 4: the middle estimate sits 6.7-fold (0.82 log units) above what was measured, outside the stated range (below it).
By their numbers in this assay, from the lowest: compound 4; then compound 3; then compound 1.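

Placing a nitro group on an aromatic carbon of the core of compound 1, meta to a chloro group and para to a large group, gives a 7.0-fold lower number from compound 1 to compound 4 (0.85 log units; beyond the scatter) in this assay. Among these compounds, this is the first look at this position, and it shows that a substituent there can lower the number rather than raise it, so the position is open to change in this test, which the earlier hydroxy step, a 2.1-fold lower number from compound 1 to compound 3 (0.32 log units; beyond the scatter), could not reveal. The size of the nitro step still rests on a single value for compound 4, and repeat measurements in this test can sit far apart, as seen in: the several entries of compound 2 in this assay, 800 nM; 3300 nM (2 entries)

An amine, a nitrile or a carboxylic acid at the same place would show whether the lower number belongs to the nitro group in particular or comes with other substituents there as well. As far as these compounds go, it also remains open whether a nitro group at this position would lower the number in the same way on a core without the chloro group.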